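Removing the triazole side group in the shared lactone series

A few compounds are considered here, and "the series" means these few. Any claim that something is new, unique, unknown or untested is made for them only; others in the source may bear on it.

Measured compounds:
compound 1, `Cc1ccc(S(=O)(=O)NCc2cn(C[C@H](O)[C@H]3OC(=O)C(OCc4ccccc4)=C3OCc3ccccc3)nn2)cc1`: 16800 nM
compound 2, `Cc1ccc(-c2cn(C[C@H](O)[C@H]3OC(=O)C(OCc4ccccc4)=C3OCc3ccccc3)nn2)cc1`: 8690 nM
compound 3, `O=C1O/C(=C\Cn2cc(-c3cc(C(F)(F)F)cc(C(F)(F)F)c3)nn2)C(OCc2ccccc2)=C1OCc1ccccc1`: > 100000 nM

In a functional assay on A549 cells (Homo sapiens) for antiproliferative activity, read by MTT assay, with a stated time of 72 h (a higher number here means a weaker inhibitor, a lower number a stronger inhibitor), compound 1 gives 16800 nM, the highest of the two numbers shown. Compound 2 sits nearest to it: a 1.9-fold lower number from compound 1 to compound 2 (0.29 log units; within the scatter), so the two are not separated by the data. Compound 3 differs in its core as well as in its aryl group; in this assay compound 3 reaches only a limit, > 100000 nM, which is one of the values described by the limit of > 100000 nM in this assay, at which 1 of the 3 values shown sits.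

Compound 4, `O=C1O[C@H]([C@@H](O)Cn2ccnn2)C(OCc2ccccc2)=C1OCc1ccccc1`, carries hydrogen in place of (((4-methylphenyl)sulfonyl)amino)methyl on an aromatic carbon, so the whole substituent on the five-membered aromatic ring with 3 nitrogen is gone. Going by the values given here, the one measured step, from compound 1 to compound 2, exchanges that substituent for another and stays within the scatter; no step removes it entirely, and compound 3 shows only that a further variant gives a limit. The expectation is therefore a weakening beyond the scatter, a 2.1-fold higher number from compound 1 to compound 4 (0.32 log units; beyond the scatter). Compound 4 is estimated at 35000 nM, within 12000 nM to 100000 nM, with a real chance of a limit only.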

Compound 4, half-maximal inhibitory concentration: > 100000 nM
Compound 4: a limit, no number (the forecaster's own chance of this, stated with the estimate: 30%); at least 2.8-fold (0.45 log units) between middle value and limit.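

In this assay compound 4 reaches only a limit, > 100000 nM, and that limit is now shared: the limit of > 100000 nM in this assay, at which 2 of the 4 values shown sit.

Going by these compounds alone, replacing the substituent with hydrogen on this aromatic carbon therefore has a clear effect, giving an at least 5.9-fold higher number from compound 1 to compound 4 (0.77 log units; beyond the scatter) and an at least 11-fold higher number from compound 2 to compound 4 (1.06 log units; beyond the scatter), whereas the two substituents of the earlier compounds were not separated by the data. Across compounds 1, 2 and 4, a measurable value goes with a substituent at this position, while compound 3 goes against this pattern, although its core also differs.

Going by these compounds, it remains open how small a group on this carbon can be while a measurable value is kept, for example a methyl group or an amine. Also open, on these data alone, is whether a longer alkyl chain or a carboxylic acid would fit the pattern.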